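Chloro for amino on a chloromethylbenzyl purine series

The source may report more compounds than this note shows. Statements on the series, on what has been measured and on what is new or still open speak of the compounds shown alone.

Compound 1, `Nc1nc(Cl)c2ncn(Cc3ccccc3CCl)c2n1`: 5620 nM
Compound 2, `ClCc1ccc(Cn2cnc3c(Cl)nc(Cl)nc32)cc1`: 20900 nM
Compound 3, `ClCc1ccccc1Cn1cnc2ncnc(Cl)c21`: 8510 nM

Of the compounds shown here, three have been tested in a functional assay on SN12C cells (Homo sapiens) for cytotoxicity, read by sulforhodamine B assay, with a stated time of 48 h; on this read-out higher numbers stand for weaker inhibition of growth and lower numbers for stronger inhibition of growth. Compound 1 gives the lowest number of the three, 5620 nM. The nearest is compound 3, which in this assay gives 8510 nM; the gap lies within the scatter, so the two cannot be ranked against each other. Furthest from compound 1 stands compound 2, which gives 20900 nM in this assay, a gap beyond the scatter. Nothing more than these two values can be said of that pair.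

Compound 4, `ClCc1ccccc1Cn1cnc2c(Cl)nc(Cl)nc21`, has not yet been measured. It differs from compound 1 by chloro in place of amino on an aromatic carbon. Compound 2 carries a chloro group at this same place but differs from compound 4 in its benzyl group, so it offers only an indirect hint. Among the compounds with values here, no step between measured compounds isolates this change. The account expects a modest step from compound 1 to compound 4, towards a somewhat higher number, of a size that may not clear the scatter: a 1.6-fold higher number from compound 1 to compound 4 (0.20 log units; within the scatter). For compound 4 in this assay an estimated 9000 nM is expected, within a range from 3000 nM to 27000 nM.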

Compound 4, concentration for total growth inhibition: 2040 nM
The estimate for compound 4 lay 4.4-fold (0.64 log units) above the measured number; measured number below the stated range.
By their numbers in this assay, from the lowest: compound 4; then compounds 1 and 3 (each within the scatter of the next); then compound 2.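

In this assay, placing chloro in place of amino on an aromatic carbon between two ring nitrogen atoms gives a 2.8-fold lower number from compound 1 to compound 4 (0.44 log units; beyond the scatter), so this position responds to the group it carries and the amino group of compound 1 is not required for inhibition of growth in this series. Within the data shown here, none of the earlier compounds formed a pair across this single change, and compound 2, which has chloro at the same place but a different benzyl group, gives 20900 nM while compound 4 gives 2040 nM, so chloro at this place does not bring a low number with both benzyl groups. Nothing measured here accounts for the step.

The compounds shown leave open how other groups at this position, such as bromo, methoxy or methylamino, would compare with chloro and amino. They also leave open whether exchanging amino for chloro would give a similar step on the benzyl group of compound 2, since only the chloro member of that pair appears here.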